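A few compounds are considered here, and "the series" means these few. Any claim that something is new, unique, unknown or untested is made for them only; others in the source may bear on it.

In a functional assay on HeLa cells (Homo sapiens) for cytotoxicity, with a stated time of 72 h (on this read-out lower numbers stand for higher toxicity in this test and higher numbers for lower toxicity in this test), compound 2 `O=C1C(N2CCCCC2)=NN(c2ccc(Cl)cc2)CN1c1ccccc1Cl` gives > 50 ug/mL, which is a limit of the assay and not a number. Compound 4 `CN(C)C1=NN(c2ccc(Cl)cc2)CN(c2ccccc2Cl)C1=O` has not been measured yet. It differs from compound 2 by dimethylamino in place of piperidin-1-yl on a carbon with a double bond to nitrogen.

The closest guide is the same exchange run in the opposite direction. Compound 1 `CN(C)C1=NN(c2ccccc2)CN(c2ccccc2Cl)C1=O` gives 39.5 ug/mL, and compound 3 `O=C1C(N2CCCCC2)=NN(c2ccccc2)CN1c1ccccc1Cl` gives 26 ug/mL. Going to the piperidin-1-yl group there produced a 1.5-fold lower number from compound 1 to compound 3 (0.18 log units; within the scatter), which is a small change. A second step, hydrogen in place of chloro on an aromatic carbon, produced an at least 1.9-fold lower number from compound 2 to compound 3 (0.28 log units; that floor lies within the scatter), and compound 4 keeps that chloro.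

No step beyond the scatter is therefore expected in this assay, and any drift should be toward a higher number, meaning lower toxicity. The estimated outcome is a step that the limit leaves unreadable from compound 2 to compound 4. Compound 4 is expected at about 55 ug/mL, within an estimated range from 30 ug/mL to 100 ug/mL, and the assay may report only a limit.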

Compound 4, half-maximal cytotoxic concentration: 39.4 ug/mL
The estimate for compound 4 lay 1.4-fold (0.14 log units) above the measured number; measured number inside the range.
By their numbers in this assay, from the lowest: compounds 3, 4 and 1 (each within the scatter of the next). At a limit, above all of these: compound 2.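

In this assay, chloro in place of hydrogen on an aromatic carbon gives a 1.0-fold lower number from compound 1 to compound 4 (0.00 log units; within the scatter), so with dimethylamino on the core, this exchange produces no step beyond the scatter: the same change on two cores in this assay, an at least 1.9-fold lower number (0.28 log units; that floor lies within the scatter) from compound 2 to compound 3 and a 1.0-fold higher number (0.00 log units; within the scatter) from compound 4 to compound 1; the limit leaves it open whether they differ

Compound 2 gives > 50 ug/mL, which is a limit of the assay and not a number.

Dimethylamino in place of piperidin-1-yl gives an at least 1.2-fold lower number from compound 2 to compound 4 (0.10 log units; that floor lies within the scatter), so the true size of this step stays unknown, and it cannot be set against the same exchange on the other core: the same change on two cores in this assay, a 1.5-fold lower number (0.18 log units; within the scatter) from compound 1 to compound 3 and an at least 1.2-fold higher number (0.10 log units; that floor lies within the scatter) from compound 4 to compound 2; the limit leaves it open whether they differ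

Still open, going by these compounds, is whether the chloro counts for more when piperidin-1-yl sits on the carbon with a double bond to nitrogen. Also open, on these data alone, is how a morpholin-4-yl or diethylamino group on that carbon would read in this assay.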